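The source may hold more compounds than are shown below. What is called first, only, known or untested is meant among the compounds shown, and "the series" means these compounds.

Compound 1 `CCn1c(C(=O)Nc2ccc(OC(F)(F)F)cc2)ccc1C(CC)(CC)c1ccc(OCCC(O)(CC)CC)c(C)c1` gives in an ADME assay on L02 cells (Homo sapiens) for antiproliferative activity, read by MTT assay, with a stated time of 48 h (on this read-out lower numbers stand for stronger inhibition and higher numbers for weaker inhibition), only a limit of the assay, > 50000 nM. Compound 2 `CCOc1ccc(NC(=O)c2ccc(C(CC)(CC)c3ccc(OCCC(O)(CC)CC)c(C)c3)n2CC)cc1` likewise gives in this assay only a limit, > 50000 nM. Among the measured compounds shown here, the step that the two limits leave unreadable from compound 1 to compound 2 thus cannot be sized; the sole evidence is the limit of > 50000 nM in this assay, at which 2 of the 2 values shown sit. Compound 3 `CCn1c(C(=O)NC(C)C(=O)O)ccc1C(CC)(CC)c1ccc(OCCC(O)(CC)CC)c(C)c1` differs from compound 1 by 1-carboxyethyl in place of 4-(trifluoromethoxy)phenyl on an amide-type nitrogen. For the measured compounds named here, only that unreadable step bears on this change, so no step of readable size in this assay is expected, and compound 3 is expected to sit at the same limit, a step that the limit leaves unreadable from compound 1 to compound 3. Compound 3 is therefore estimated at 60000 nM, within 20000 nM to 200000 nM.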

Compound 3, half-maximal inhibitory concentration: 4040 nM
Compound 3: middle estimate off by 15-fold (1.17 log units), on the high side, and the stated range ends above it.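

The amide-type nitrogen position can move the number in this assay: 1-carboxyethyl gives an at least 12-fold lower number from compound 1 to compound 3 (1.09 log units; beyond the scatter), and the comparison with the 4-ethoxyphenyl group gives an at least 12-fold lower number from compound 2 to compound 3 (1.09 log units; beyond the scatter). The earlier pair showed no readable effect here, and the step between its two aromatic groups cannot be read, with both compounds at a limit: the limit of > 50000 nM in this assay, at which 2 of the 3 values shown sit.

Compound 3 loses the aromatic ring and gains the 1-carboxyethyl group in one change, and the compounds shown cannot separate these two parts. Going by these compounds, how an amine or a longer chain carrying the carboxylic acid would read at this position stays open.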